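A few compounds are considered here, and "the series" means these few. Any claim that something is new, unique, unknown or untested is made for them only; others in the source may bear on it.

In a functional assay on G-361 cells (Homo sapiens) for cytotoxicity, read by fluorescence, with a stated time of 72 h (on this read-out higher numbers stand for weaker inhibition and lower numbers for stronger inhibition), compound 1 `CC(C)c1n[nH]c2c(NCc3ccc(-c4ccccn4)cc3)nc(NCCO)nc12` gives 39 nM and compound 2 `CC(C)c1n[nH]c2c(NCc3ccc(-c4ccccn4)cc3)nc(NCC(C)(C)O)nc12` gives 48 nM, with a 1.2-fold higher number from compound 1 to compound 2 (0.09 log units; within the scatter). Compound 3 `CC(C)c1n[nH]c2c(NCc3ccc(-c4ccccn4)cc3)nc(NCCN(C)C)nc12`, at 640 nM, has the highest number of the three, with a 16-fold higher number from compound 1 to compound 3 (1.22 log units; beyond the scatter) and a 13-fold higher number from compound 2 to compound 3 (1.12 log units; beyond the scatter). Compound 4 `CC(C)c1n[nH]c2c(NCc3ccc(-c4ccccn4)cc3)nc(NCc3ccc(-c4ccccn4)cc3)nc12` carries 4-(pyridin-2-yl)phenyl in place of (dimethylamino)methyl on a saturated chain carbon bound to a nitrogen on an aromatic ring. The two large steps bear only indirectly. Both end at compound 3, and compound 4, like compound 3, has no hydroxy group. Among the compounds with values here, no measured compound carries the entering group at this place, so no step beyond the scatter is expected in either direction. The expected result is a 1.3-fold lower number from compound 3 to compound 4 (0.11 log units; within the scatter), with wide uncertainty. Compound 4 is estimated at 500 nM, within 60 nM to 4000 nM.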

Compound 4, half-maximal inhibitory concentration: 3610 nM
The estimate for compound 4 lay 7.2-fold (0.86 log units) below the measured number; the range from low to high includes it.
By their numbers in this assay, from the lowest: compounds 1 and 2 (each within the scatter of the next); then compound 3; then compound 4.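

In this assay, a second group without a hydroxy group also gives a higher number: 4-(pyridin-2-yl)phenyl in place of (dimethylamino)methyl gives a 5.6-fold higher number from compound 3 to compound 4 (0.75 log units; beyond the scatter). Against the two hydroxy chains, the same group gives a 75-fold higher number from compound 2 to compound 4 (1.88 log units; beyond the scatter) and a 93-fold higher number from compound 1 to compound 4 (1.97 log units; beyond the scatter), so both non-hydroxy groups, the chain amine and the aromatic group, stand well above compounds 1 and 2 at this place. No measurement at hand accounts for these steps.

From the compounds shown here alone, whether the hydroxy group itself or merely the short chain carrying it matters stays open. A methyl ether, a primary amine or a carboxylic acid on the same chain would bear on this.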